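A few compounds are considered here, and "the series" means these few. Any claim that something is new, unique, unknown or untested is made for them only; others in the source may bear on it.

In an ADME assay on microsomes from liver (Rattus norvegicus) for metabolic stability (on this read-out lower numbers stand for a shorter-lived compound and higher numbers for a longer-lived compound), compound 2 (`CC(C)n1ncc2c(=O)n(Cc3ccccc3)c(N[C@H](C)c3ccc(Cl)cc3)nc21`) stands highest of the two numbers at 0.04 h and compound 1 (`C[C@@H](Nc1nc2c(cnn2C2CCCC2)c(=O)n1Cc1ccccc1)c1ccc(Cl)cc1`) lies lower at 0.00833 h on the same read-out. Compound 3 (`CC(C)n1ncc2c(=O)n(C)c(N[C@H](C)c3ccc(Cl)cc3)nc21`) has hydrogen in place of phenyl on a saturated chain carbon bound to an aromatic nitrogen. For the measured compounds named here, the only measured step (a 4.8-fold higher number from compound 1 to compound 2 (0.68 log units; beyond the scatter)) put isopropyl in place of cyclopentyl on an aromatic nitrogen, a different place, so it is only a loose guide. Going by it, a modest upward move of similar size is expected (a 3.8-fold higher number from compound 2 to compound 3 (0.57 log units; beyond the scatter)). For compound 3 the estimated value is 0.15 h and 0.05 h to 0.5 h is the expected range.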

Compound 3, half-life: 0.0367 h
Estimate against measurement, compound 3: 4.1-fold (0.61 log units) above, and the stated range ends above it.
By their numbers in this assay, from the lowest: compound 1; then compounds 3 and 2 (each within the scatter of the next).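

In this assay, cutting benzyl back to methyl gives a 1.1-fold lower number from compound 2 to compound 3 (0.04 log units; within the scatter), so the phenyl at this place can go without a shift in half-life beyond the scatter. This contrasts with the isopropyl in place of cyclopentyl change, which gave a 4.8-fold higher number from compound 1 to compound 2 (0.68 log units; beyond the scatter), so in these compounds the read-out responds to that change but not to this one. No supporting data bear on why the phenyl makes no difference here. Open, as far as these compounds go, is whether an amine or a carboxylic acid at this place would move the half-life beyond the scatter. From the compounds shown here alone, a longer chain here is equally open.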